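Tetrazolyl for Trifluoromethyl-Triazolyl on the Dioxolane Side Chain

The compounds below may be only part of what the source reports. "The series", "measured", "known", "first", "only" and "open" are said of these compounds alone.

Of the compounds shown here, three sharing one core have been tested in a functional assay on HUVEC cells (Homo sapiens), read by scintillation counting and thymidine incorporation, with a stated time of 24 h; a higher number here means a weaker inhibitor, a lower number a stronger inhibitor. Compound 1 `CCC(C)n1ncn(-c2ccc(N3CCN(c4ccc(OC[C@@H]5CO[C@@](Cc6ccccc6)(c6ccc(Cl)cc6Cl)O5)cc4)CC3)cc2)c1=O` gives 513 nM. Compound 2 `CCC(C)n1ncn(-c2ccc(N3CCN(c4ccc(OC[C@@H]5CO[C@@](Cn6cnc(C(F)(F)F)n6)(c6ccc(Cl)cc6Cl)O5)cc4)CC3)cc2)c1=O` gives 270 nM, and compound 3 `CCC(C)n1ncn(-c2ccc(N3CCN(c4ccc(OC[C@@H]5CO[C@@](Cn6ccnc6C(C)C)(c6ccc(Cl)cc6Cl)O5)cc4)CC3)cc2)c1=O` gives 84 nM. On these numbers compound 2 stands second highest of the three; its nearest neighbour is compound 1, with a 1.9-fold lower number from compound 1 to compound 2 (0.28 log units; within the scatter), while a 3.2-fold lower number from compound 2 to compound 3 (0.51 log units; beyond the scatter) and a 6.1-fold lower number from compound 1 to compound 3 (0.79 log units; beyond the scatter) are the two steps that reach beyond the scatter.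

The next compound, compound 4 `CCC(C)n1ncn(-c2ccc(N3CCN(c4ccc(OC[C@@H]5CO[C@@](Cn6ncnn6)(c6ccc(Cl)cc6Cl)O5)cc4)CC3)cc2)c1=O`, differs from compound 2 in one place: 2H-tetrazol-2-yl in place of 3-(trifluoromethyl)-1H-1,2,4-triazol-1-yl on a saturated chain carbon bound to a saturated ring carbon. Among the measured compounds shown here, none of the measured steps exchanges one five-membered aromatic ring for another of this kind; the steps that exist either swap phenyl for a heteroaromatic ring or swap the two heteroaromatic rings of compound 2 and compound 3, and only the latter pair moved beyond the scatter. This change removes the trifluoromethyl as well as altering the ring, so its effect is not anchored by any measured pair.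

Compound 4 is therefore expected to sit near compound 2, with a 1.3-fold higher number from compound 2 to compound 4 (0.11 log units; within the scatter) not beyond the scatter. The estimate for compound 4 in this assay is 350 nM, within a range of 120 nM to 1000 nM.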

Compound 4, half-maximal inhibitory concentration: 124 nM
Compound 4: the middle estimate sits 2.8-fold (0.45 log units) above what was measured; the range from low to high includes it.
By their numbers in this assay, from the lowest: compounds 3 and 4 (each within the scatter of the next); then compounds 2 and 1 (each within the scatter of the next).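

In this assay, 2H-tetrazol-2-yl in place of 3-(trifluoromethyl)-1H-1,2,4-triazol-1-yl gives a 2.2-fold lower number from compound 2 to compound 4 (0.34 log units; beyond the scatter), so at this position the number can go down with the trifluoromethyl gone. Measured against the other two side chains, the same ring gives a 4.1-fold lower number from compound 1 to compound 4 (0.62 log units; beyond the scatter) and a 1.5-fold higher number from compound 3 to compound 4 (0.17 log units; within the scatter), so among these four compounds a five-membered aromatic ring needs no substituent to match the 2-isopropyl-1H-imidazol-1-yl of compound 3, although compound 1, whose phenyl is also unsubstituted, goes against any reading that lack of a substituent alone is enough. No supporting data on why this exchange moves the number are available.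

On these data alone, whether 1H-1,2,4-triazol-1-yl without its trifluoromethyl would read like compound 2 or like compound 4 remains open, so the loss of the trifluoromethyl and the change of ring cannot be separated. As far as these compounds go, how an amine such as dimethylamino would read at this place is also open.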